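The source may hold more compounds than are shown below. What is called first, only, known or untested is meant among the compounds shown, and "the series" means these compounds.

Measured so far:
compound 1, `CC(C)CC1n2cncc2CN([C@@H](C)c2ccc(Cl)cc2)S1(=O)=O`: 9.4 nM
compound 2, `C[C@@H](c1ccc(Cl)cc1)N1Cc2cncn2C(C[C@H](O)c2ccccc2)S1(=O)=O`: 0.3 nM

Both compounds were tested in an assay on cells for inhibition of cytochrome P450 11B2, mitochondrial (Homo sapiens); on this read-out lower numbers stand for stronger inhibition and higher numbers for weaker inhibition. Within the data shown here, compound 1 stands highest of the two numbers; its only neighbour is compound 2, and the step of a 31-fold lower number from compound 1 to compound 2 (1.50 log units; beyond the scatter) accompanied the exchange of hydroxy(phenyl)methyl in place of isopropyl on a saturated chain carbon bound to a saturated ring carbon.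

Compound 3, `CC(C)CC1n2cncc2CN([C@H](C)c2ccc(Cl)cc2)S1(=O)=O`, has not yet been measured. Its relation to compound 1 is purely spatial: the two compounds have the same atoms and bonds; at least one stereo element is drawn with a configuration in one of them and without one in the other: 1 of 2 stereo elements differ; a stereocentre at a saturated chain carbon is drawn S in compound 1 and R in compound 3. No atom leaves and none enters; only the handedness at that one carbon is reversed. Among the measured compounds shown here, the single measured step, the one from compound 1 to compound 2, concerns a different part of the molecule and says nothing about reversing a stereocentre, so no measured step bears on this change and the expectation rests on little. Mirror-image changes of this kind can leave the number unchanged or shift it a great deal in either direction; a weaker result is taken as the more likely outcome, with a wide range. For compound 3 the estimate is 60 nM, spanning 8 nM to 500 nM. That estimate means an expected step of a 6.4-fold higher number from compound 1 to compound 3 (0.81 log units; beyond the scatter).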

Compound 3, half-maximal inhibitory concentration: 61.7 nM
The estimate for compound 3 lay 1.0-fold (0.01 log units) below the measured number, and the stated range covers the measured number.
By their numbers in this assay, from the lowest: compound 2; then compound 1; then compound 3.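

Reversing the stereocentre at a saturated chain carbon from S to R, with no atom gained or lost, gives a 6.6-fold higher number from compound 1 to compound 3 (0.82 log units; beyond the scatter) in this assay. Among these compounds, the earlier pair showed only that exchanging one group for another can move the number; this pair shows that the number also responds to spatial arrangement alone, and that the S form is the one with the lower number here. The only recorded point bearing on this gap is the following: the fact that one of compounds 1 and 3 is drawn with a defined configuration and the other without, at the place where they differ

The compounds shown leave open whether the same reversal would produce a similar step with hydroxy(phenyl)methyl in place of isopropyl, as in compound 2, whose R counterpart does not appear here. They also leave open how the number would respond to a longer chain in place of the methyl group on this stereocentre, and whether either hand would still give a number in this range.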